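A few compounds are considered here, and "the series" means these few. Any claim that something is new, unique, unknown or untested is made for them only; others in the source may bear on it.

Measured compounds in a functional assay on HeLa cells (Homo sapiens) for antiproliferative activity, read by MTT assay, with a stated time of 72 h; on this read-out lower numbers stand for stronger inhibition and higher numbers for weaker inhibition:
compound 1, `COc1ccc(-n2ncnc2-c2cc(OC)c(OC)c(OC)c2)cc1`, > 10000 nM
compound 2, `COc1cc(-c2ncnn2-c2ccc(Cl)c(Cl)c2)cc(OC)c1OC`, > 10000 nM

Compound 1 stands at the assay limit: its value of > 10000 nM in this assay is a limit and not a number. Compound 2, in which a 3,4-dichlorophenyl replaces the 4-methoxyphenyl on an aromatic nitrogen of the shared core, also gives only a limit, > 10000 nM. Going by the values given here, the one measured step, a step that the two limits leave unreadable from compound 1 to compound 2, is therefore of unreadable size; both values sit where the limit of > 10000 nM in this assay, at which 2 of the 2 values shown sit, describes.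

Compound 3, `COc1cc(-c2ncnn2-c2ccc([N+](=O)[O-])cc2)cc(OC)c1OC`, is not yet measured. It differs from compound 1 by nitro in place of methoxy on an aromatic carbon. Among the compounds with values here, no measured step touches this position, and the only step is the unreadable one from compound 1 to compound 2. Nothing measured points to a readable gain. Compound 3 is expected to stay at or around the assay limit, and the step that the limit leaves unreadable from compound 1 to compound 3 is an estimate resting on nothing more than the limits seen so far. For compound 3 the expected value in this assay is 15000 nM, within a range of 4000 nM to 60000 nM, with a high chance that only a limit is reported.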

Compound 3, half-maximal inhibitory concentration: > 10000 nM
Compound 3 ended at the assay's limit; the forecaster's own chance of this, stated with the estimate: 75%; the middle value lies beyond the limit too.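

No step can be read between compound 1 and compound 3 in this assay, where nitro in place of methoxy leaves both compounds with only a limit. The series shown sits at one value: the limit of > 10000 nM in this assay, at which 3 of the 3 values shown sit.

The compounds shown leave open whether any group on the shared core gives a measurable value in this assay.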